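The source may report more compounds than this note shows. Statements on the series, on what has been measured and on what is new or still open speak of the compounds shown alone.

The measured compounds:
- compound 1 `CC[C@H](C)[C@H](N)CN(C(=O)[C@@H]1C[C@H]1c1ccccc1)c1ccc(-c2ccccc2)cc1`: in a functional assay for agonist activity at G protein-coupled receptor 88 (Homo sapiens), read by HTRF and cAMP accumulation (on this read-out lower numbers stand for an effect already at smaller amounts and higher numbers for an effect only at larger amounts of compound), compound 1 gives 230 nM; 800 nM (2 entries)
- compound 2 `CCOc1ccc(-c2ccc(N(C[C@@H](N)[C@@H](C)CC)C(=O)[C@@H]3C[C@H]3c3ccccc3)cc2)cc1`: compound 2 gives 90 nM
- compound 3 `CC[C@H](C)[C@H](N)CN(C(=O)[C@@H]1C[C@H]1c1ccccc1)c1ccc(-c2ccc(OC)cc2)cc1`: compound 3 gives 120 nM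

Compound 3 carries the higher of the two single numbers in this assay, but its nearest neighbour, compound 2, sits within the scatter of it, so no order between the two can be read. Compound 1 has no single number; the several entries of compound 1 in this assay, 230 nM; 800 nM (2 entries) spread wider than the scatter, and nothing more can be said of that pair.

Compound 4, `CC[C@H](C)[C@H](N)CN(C(=O)[C@@H]1C[C@H]1c1ccccc1)c1ccc(-c2ccc(OC(F)(F)F)cc2)cc1`, differs from compound 3 in one place: trifluoromethyl in place of methyl on an oxygen on an aromatic ring. Among the compounds with values here, only one measured step touches this part of the molecule, the change from ethoxy to methoxy, which gave a 1.3-fold higher number from compound 2 to compound 3 (0.12 log units; within the scatter). That step is small and does not concern a trifluoromethyl, so it offers only a weak guide. On that basis the step to compound 4 is expected to stay within the scatter in this assay, with no direction that can be foreseen, and the expected change is a 1.3-fold higher number from compound 3 to compound 4 (0.10 log units; within the scatter). For compound 4 the estimate in this assay is 150 nM, within a range from 50 nM to 500 nM.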

Compound 4, half-maximal effective concentration: 170 nM
Compound 4: the middle estimate sits 1.1-fold (0.05 log units) below what was measured, and the stated range covers the measured number.
By their numbers in this assay, from the lowest: compounds 2, 3 and 4 (each within the scatter of the next).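

In this assay, the earlier step at this place had only exchanged ethyl for methyl on the oxygen on the aromatic ring, whereas compound 4 brings in fluorine: trifluoromethyl in place of methyl gives a 1.4-fold higher number from compound 3 to compound 4 (0.15 log units; within the scatter). Trifluoromethyl in place of ethyl gives a 1.9-fold higher number from compound 2 to compound 4 (0.28 log units; within the scatter), so ethyl, methyl and trifluoromethyl on this oxygen cannot be told apart in this read-out, and a fluorinated group here is no exception among these three compounds. Nothing at hand explains why these exchanges leave the numbers within the scatter.

What the compounds shown leave open is whether the same holds for groups of another kind on this aromatic ring, such as an amine, a carboxylic acid, a nitrile or a longer chain on the oxygen. They also do not tell whether the exchange of methyl for trifluoromethyl would read the same with a change elsewhere on the shared core, since all three compounds differ only at this one place.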